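A few compounds are considered here, and "the series" means these few. Any claim that something is new, unique, unknown or untested is made for them only; others in the source may bear on it.

- compound 1 (`C=CC(=O)Nc1cccc(Oc2nc(Nc3ccn(C)n3)nc3c2CSCC3)c1`): 18600 nM
- compound 2 (`C=CC(=O)Nc1cccc(Oc2nc(Nc3cccc(OC)c3)nc3c2CSCC3)c1`): 10100 nM
- compound 3 (`C=CC(=O)Nc1cccc(Oc2nc(Nc3cccc(C#N)c3)nc3c2CSCC3)c1`): 6860 nM

These values come from a functional assay on A549 cells (Homo sapiens) for antiproliferative activity, read by MTT assay, with a stated time of 72 h (a higher number here means a weaker inhibitor, a lower number a stronger inhibitor), and the three compounds share one core. The standing of compound 3 rests on two steps: a 2.7-fold lower number from compound 1 to compound 3 (0.43 log units; beyond the scatter) is a modest separation, whereas a 1.5-fold lower number from compound 2 to compound 3 (0.17 log units; within the scatter) does not separate the pair.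

Compound 4 (`C=CC(=O)Nc1cccc(Oc2nc(Nc3ccc(OC)cc3)nc3c2CSCC3)c1`) carries 4-methoxyphenyl in place of 3-cyanophenyl on a nitrogen on an aromatic ring and has not yet been measured. For the measured compounds named here, no measured compound carries this group, so the evidence is indirect. The closest guide is the exchange of methoxy for cyano, where a 1.5-fold lower number from compound 2 to compound 3 (0.17 log units; within the scatter) stays small, and a 1.8-fold lower number from compound 1 to compound 2 (0.27 log units; within the scatter) is also small. A slight move toward a higher number in this assay is therefore expected, probably not beyond the scatter. The expected step is a 1.5-fold higher number from compound 3 to compound 4 (0.16 log units; within the scatter) on this estimate. For compound 4 the estimated value is 10000 nM with an expected range from 4500 nM to 22000 nM in repeated measurements.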

Compound 4, half-maximal inhibitory concentration: 4220 nM
Beside the measured number, compound 4's estimate is 2.4-fold (0.37 log units) above it; measured number outside the range, below it.
By their numbers in this assay, from the lowest: compounds 4, 3, 2 and 1 (each within the scatter of the next, the first and the last beyond it).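

In this assay, for the compounds shown here, the step from the 3-methoxyphenyl of compound 2 to the 4-methoxyphenyl of compound 4 is the first comparison of two placements of one group on this aromatic ring, and a 2.4-fold lower number from compound 2 to compound 4 (0.38 log units; beyond the scatter) is a modest separation. The exchange of 3-cyanophenyl for 4-methoxyphenyl does not separate its pair, with a 1.6-fold lower number from compound 3 to compound 4 (0.21 log units; within the scatter) as the printed step. Against the 1-methyl-1H-pyrazol-3-yl group, a 4.4-fold lower number from compound 1 to compound 4 (0.64 log units; beyond the scatter) is the largest step in the set, though it remains modest.

The compounds shown leave open whether a 4-ethoxyphenyl, 4-aminophenyl or 4-carboxyphenyl group at this place would follow compound 4, and whether the 4-methoxyphenyl result would hold on a different shared core. No measurement given here explains these differences.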